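The source may report more compounds than this note shows. Statements on the series, on what has been measured and on what is new or still open speak of the compounds shown alone.

Measured compounds:
compound 1, `O=S(=O)(/C=C/c1ccc(F)cc1)Cc1ccc(Nc2ncnc3ccccc23)cc1`, 16000 nM in a functional assay on MCF7 cells (Homo sapiens); on this read-out lower numbers stand for stronger inhibition of growth and higher numbers for weaker inhibition of growth
compound 2, `O=S(=O)(/C=C/c1ccc(Cl)cc1Cl)Cc1ccc(Nc2ncnc3ccccc23)cc1`, 4000 nM in this assay
compound 3, `O=S(=O)(/C=C/c1ccc(F)cc1Cl)Cc1ccc(Nc2ncnc3ccccc23)cc1`, 21000 nM in this assay

Of the compounds shown here, three sharing one core have been tested for growth inhibition of breast cancer cells. The core of compound 2 differs from that of compound 1 by 2,4-dichlorophenyl in place of 4-fluorophenyl on a double-bonded chain carbon bound to a double-bonded chain carbon, and this change gives a 4.0-fold lower number from compound 1 to compound 2 (0.60 log units; beyond the scatter). Compound 3 differs from compound 1 by chloro in place of hydrogen on an aromatic carbon, which gives a 1.3-fold higher number from compound 1 to compound 3 (0.12 log units; within the scatter). Between compound 2 and compound 3 the step is a 5.3-fold higher number from compound 2 to compound 3 (0.72 log units; beyond the scatter). Compound 2 has the lowest number of the three, and its steps to the two others both lie beyond the scatter.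

Compound 4, `O=S(=O)(/C=C/c1ccc(Cl)cc1Cl)Cc1ccc(Nc2ncnc3cc(Cl)ccc23)cc1`, is not yet measured. It differs from compound 2 by chloro in place of hydrogen on an aromatic carbon. Within the data shown here, this is the same kind of change as the one from compound 1 to compound 3, but not the same: there the chloro entered ortho to a large group and meta to a fluoro group on a ring of carbon only, whereas in compound 4 it enters a ring that is part of a fused or bridged system of two rings, meta to a fused ring and para to a fused ring. Among the measured compounds shown here, the one measured example of this kind of change, a 1.3-fold higher number from compound 1 to compound 3 (0.12 log units; within the scatter), stayed within the scatter. Resting on that step, a step of a 1.1-fold higher number from compound 2 to compound 4 (0.05 log units; within the scatter) is expected for compound 4 in this assay. Compound 4 is therefore estimated at 4500 nM, with a range from 1500 nM to 14000 nM, because the step of a 1.3-fold higher number from compound 1 to compound 3 (0.12 log units; within the scatter) gives no reason to expect a large shift.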

Compound 4, concentration for 50% growth inhibition: 25000 nM
Beside the measured number, compound 4's estimate is 5.6-fold (0.74 log units) below it; measured number outside the range, above it.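

In this assay, chloro in place of hydrogen on an aromatic carbon gives a 6.3-fold higher number from compound 2 to compound 4 (0.80 log units; beyond the scatter), and this step does not match the earlier step of the same kind: the same change on two cores in this assay, a 1.3-fold higher number (0.12 log units; within the scatter) from compound 1 to compound 3 and a 6.3-fold higher number (0.80 log units; beyond the scatter) from compound 2 to compound 4, 4.8-fold (0.68 log units) apart, beyond the scatter of two such steps

Among these compounds, this shows that, in this series, the size of the step seen for this change on one core could not be carried over to another: a step within the scatter on the first pair gave no guide to the step on the second. It does not show that the core alone sets the size of the step, since the chloro enters a ring that is part of a fused or bridged system of two rings in compound 4 but a different ring, of carbon only, in compound 3, and with one pair for each place the compounds shown cannot separate the place of the chloro from the rest of the structure.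

From the compounds shown here alone, it remains open how chloro at this same place on the fused ring would behave on the core of compound 1, which would set the two places apart. Going by these compounds, it is also open whether a methoxy group or an amine at that place would give a step of similar size to that of chloro.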